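Swapping acetyl for dimethylamino in a pyrazole cytotoxicity series

The source may hold more compounds than are shown below. What is called first, only, known or untested is meant among the compounds shown, and "the series" means these compounds.

Measured compounds:
Compound 1, `COc1cc(C)cc(-c2c(-c3ccnc(-c4ccc(C(C)=O)cc4)c3)cnn2CC#N)c1`, 34%
Compound 2, `COc1cc(C)cc(-c2nn(CC#N)cc2-c2ccc(-c3cccc(C(C)=O)c3)nc2)c1`, 22%
Compound 3, `Cc1cc(O)cc(-c2nn(CC#N)cc2-c2ccnc(-c3ccc(Oc4ccccc4)cc3)c2)c1`, 6%

Of the compounds shown here, three have been tested in a functional assay on SK-MEL-2 cells (Homo sapiens) for cytotoxicity, read by sulforhodamine B assay, with a stated time of 48 h, tested at 1 uM; a higher number here means a weaker effect of the compound at the concentration tested, a lower number a stronger effect. Compound 1 gives 34%, the highest of the three numbers, so it has the weakest effect at this concentration. Compound 2 gives 22%, a number lower than compound 1 by more than the scatter, and compound 3 gives 6%, lower still and well beyond the scatter from compound 1. No pair among these compounds differs in only one place, so no single change can be tied to any of the gaps.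

Compound 4, `COc1cc(C)cc(-c2c(-c3ccnc(-c4ccc(N(C)C)cc4)c3)cnn2CC#N)c1`, has not yet been measured. It differs from compound 1 in one place: dimethylamino in place of acetyl on an aromatic carbon. Among the measured compounds shown here, nothing among the measured compounds shows what such a swap does in this assay, so the step is expected to be small, with no clear direction, and likely within the scatter. For compound 4 the number in this assay is estimated at 30%, with a range from 8% to 55%, which would mean a step of a number 4 percentage points lower from compound 1 to compound 4 (within the scatter).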

Compound 4, a percentage reported as activity, at one concentration (the size of the read-out at that concentration, not a potency): 11%
Estimate against measurement, compound 4: 19 percentage points above; the measured number falls inside the stated range.
By their numbers in this assay, from the lowest: compounds 3 and 4 (each within the scatter of the next); then compound 2; then compound 1.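

In this assay, among the compounds shown here, dimethylamino in place of acetyl gives the first change that can be tied to a single place: a number 23 percentage points lower from compound 1 to compound 4 (beyond the scatter). The position on the aromatic carbon para to a large group is therefore not indifferent to what it carries, since a lower number here means a stronger effect, and the two groups match in their counts of heavy atoms and hydrogen-bond acceptors. Nothing measured on these compounds speaks to what lies behind the step.

This single step leaves open whether another group at the same position, such as a primary amine, a methoxy group or a morpholine ring, would give a similar number. It also leaves open whether the same swap would move the number in the same way in compound 2, which carries acetyl as well.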